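The source may hold more compounds than are shown below. What is called first, only, known or untested is meant among the compounds shown, and "the series" means these compounds.

Measured compounds in an assay on tissue (HeLa cells) for inhibition of Indoleamine 2,3-dioxygenase 1 (Homo sapiens), read by spectrophotometry; a lower number here means a stronger inhibitor, a higher number a weaker inhibitor:
compound 1 `O/N=C(/Nc1cccc(Br)c1)c1ccc2occc2c1` gives 1100 nM
compound 2 `O/N=C(/Nc1cccc(C(F)(F)F)c1)c1ccc2occc2c1` gives 1900 nM
compound 3 `O/N=C(/Nc1ccc(F)c(Br)c1)c1ccc2occc2c1` gives 2600 nM

Compound 1 and compound 2 differ by trifluoromethyl in place of bromo on an aromatic carbon; the step in this assay is a 1.7-fold higher number from compound 1 to compound 2 (0.24 log units; within the scatter). Compound 3 differs from compound 1 by fluoro in place of hydrogen on an aromatic carbon, and the step is a 2.4-fold higher number from compound 1 to compound 3 (0.37 log units; beyond the scatter). Compound 3 has the highest number of the three; against compound 2 the gap is within the scatter.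

Compound 4 `O/N=C(/Nc1ccc(F)c(C(F)(F)F)c1)c1ccc2occc2c1` is not yet measured. It differs from compound 3 by trifluoromethyl in place of bromo on an aromatic carbon. This is the same kind of change as that from compound 1 to compound 2, not the same: here the place is ortho to a fluoro group, which the earlier pair lacks. Among the compounds with values here, the expected step is a 1.6-fold higher number from compound 3 to compound 4 (0.21 log units; within the scatter), set beside the earlier 1.7-fold higher number from compound 1 to compound 2 (0.24 log units; within the scatter), which is the only guide in hand. Compound 4 is therefore estimated at 4200 nM in this assay.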

Compound 4, half-maximal inhibitory concentration: 2200 nM
Compound 4: middle estimate off by 1.9-fold (0.28 log units), on the high side; low and high end bracket the measured number.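

In this assay trifluoromethyl in place of bromo gives a 1.2-fold lower number from compound 3 to compound 4 (0.07 log units; within the scatter) on the core carrying fluoro, and this step does not differ from the earlier one beyond the scatter: the same change on two cores in this assay, a 1.7-fold higher number (0.24 log units; within the scatter) from compound 1 to compound 2 and a 1.2-fold lower number (0.07 log units; within the scatter) from compound 3 to compound 4, 2.0-fold (0.31 log units) apart, within the scatter of two such steps.
Fluoro in place of hydrogen gives a 1.2-fold higher number from compound 2 to compound 4 (0.06 log units; within the scatter) on the core carrying trifluoromethyl, and it likewise stays within the scatter of its earlier counterpart: the same change on two cores in this assay, a 2.4-fold higher number (0.37 log units; beyond the scatter) from compound 1 to compound 3 and a 1.2-fold higher number (0.06 log units; within the scatter) from compound 2 to compound 4, 2.0-fold (0.31 log units) apart, within the scatter of two such steps.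
Both changes therefore carry between these cores with no difference that can be resolved, but a single pair of steps for each change does not show that the steps are equal or that they would hold on any other core.

On these data alone, it remains open how an amine or a carboxylic acid would compare with bromo and trifluoromethyl at this place. As far as these compounds go, a longer chain there is equally open.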